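The source may hold more compounds than are shown below. What is called first, only, known or untested is meant among the compounds shown, and "the series" means these compounds.

Of the compounds shown here, three built on one shared core have so far been tested in a functional assay on MCF7 cells (Homo sapiens) for inhibition, read by MTT assay, with a stated time of 72 h; a lower number here means a stronger inhibitor, a higher number a weaker inhibitor. Compound 1 `CC(C)c1ccc(-c2nc(SCc3cn(CC(=O)NC(=O)Nc4ccccn4)nn3)nc(Nc3ccc(Cl)cc3)c2C#N)cc1` carries a 4-chlorophenyl group on the anilino nitrogen; in this assay compound 1 gives only a limit, > 64000 nM. Compound 2 `CC(C)c1ccc(-c2nc(SCc3cn(CC(=O)NC(=O)Nc4ccccn4)nn3)nc(Nc3cccc([N+](=O)[O-])c3)c2C#N)cc1` carries a 3-nitrophenyl group there, and in this assay compound 2 gives 25900 nM. Compound 3 `CC(C)c1ccc(-c2nc(SCc3cn(CC(=O)NC(=O)Nc4ccccn4)nn3)nc(Nc3ccccc3)c2C#N)cc1` carries a plain phenyl group in that place. In this assay compound 3 likewise gives only a limit, > 64000 nM.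

The steps read as follows: an at least 2.4-fold lower number from compound 1 to compound 2 (0.39 log units; beyond the scatter), an at least 2.4-fold higher number from compound 2 to compound 3 (0.39 log units; beyond the scatter), and a step that the two limits leave unreadable from compound 1 to compound 3. Compound 3 thus sits at the weak end of what has been seen, alongside compound 1, both at the limit of > 64000 nM in this assay, at which 2 of the 3 values shown sit.

Compound 4 `Cc1ccc(Nc2nc(SCc3cn(CC(=O)NC(=O)Nc4ccccn4)nn3)nc(-c3ccc(C(C)C)cc3)c2C#N)cc1` differs from compound 3 in one place: methyl in place of hydrogen on an aromatic carbon. Among the measured compounds shown here, none of the measured steps adds a methyl group, and the only step that removed a group from this ring, the one from compound 2 to compound 3, went toward a weaker number and ended at a limit. A methyl group is a small change, so the step that the limit leaves unreadable from compound 3 to compound 4 is expected to be small or none beyond the scatter, with compound 4 likely remaining at a limit. Compound 4 is estimated at 80000 nM, within a range from 25000 nM to 250000 nM.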

Compound 4, half-maximal inhibitory concentration: > 64000 nM
Compound 4: a limit, no number (the forecaster's own chance of this, stated with the estimate: 70%); the middle value lies beyond the limit too.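

A methyl group on the aromatic ring, para to a large group, does not bring this series to a measurable number, so the plain phenyl group of compound 3 gains nothing visible from this small addition. Among the compounds shown here, the 3-nitrophenyl group of compound 2 remains the only group on this nitrogen among the four compounds that gives a number rather than a limit, with an at least 2.4-fold higher number from compound 2 to compound 4 (0.39 log units; beyond the scatter). The steps among compound 1, compound 3 and compound 4 cannot be read, so methyl, chloro and hydrogen cannot be put in any order, and most of the set now rests at one limit: the limit of > 64000 nM in this assay, at which 3 of the 4 values shown sit.

From the compounds shown here alone, it remains open whether the measured number of compound 2 is tied to the nitro group itself or would also appear with another group on this ring, such as an amine, a carboxylic acid or a methoxy group. Also open, going by these compounds, is whether a change away from this ring, such as a longer chain on the sulfur, would bring compound 4 or its neighbours to a measurable number in this assay.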